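Removing One Methyl from a Ring-Nitrogen Substituent

This account rests on a few compounds, and the source may have more. Where it says the series, first, only, none or still open, it means among the compounds named here.

Measured compounds:
Compound 1, `COc1ccc(/C=C2\CN(C)C/C(=C\c3ccc(OC)c(OC)c3)C2=O)cc1OC`, 18200 nM
Compound 2, `CCN1C/C(=C\c2ccc(OC)c(OC)c2)C(=O)/C(=C/c2ccc(OC)c(OC)c2)C1`, 9800 nM
Compound 3, `COc1cc(/C=C2\CN(C(=O)C(C)C)C/C(=C\c3cc(OC)c(OC)c(OC)c3)C2=O)cc(OC)c1OC`, 12200 nM

All three were tested in an ADME assay on L02 cells (Homo sapiens) for cytotoxicity, read by MTT assay, with a stated time of 72 h; on this read-out higher numbers stand for weaker inhibition and lower numbers for stronger inhibition. Compound 1 gives 18200 nM, compound 2 gives 9800 nM, and compound 3 gives 12200 nM. Compound 1 and compound 2 differ in one place: hydrogen in place of methyl on a saturated chain carbon bound to an amine nitrogen in a ring. The step between them, a 1.9-fold higher number from compound 2 to compound 1 (0.27 log units; within the scatter), is small and lies within the scatter of this kind of measurement, so the two values cannot be told apart with confidence.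

Compound 4, `CCC(=O)N1C/C(=C\c2cc(OC)c(OC)c(OC)c2)C(=O)/C(=C/c2cc(OC)c(OC)c(OC)c2)C1`, has not yet been measured in this assay. It differs from compound 3 in one place: hydrogen in place of methyl on a saturated chain carbon bound to a carbonyl carbon and a saturated chain carbon. Going by the values given here, this is the same kind of change as the one from compound 2 to compound 1, a methyl being replaced by hydrogen, but the place is not the same: in compound 2 the methyl sits on a saturated chain carbon bound to an amine nitrogen in a ring, whereas in compound 3 it sits on a saturated chain carbon bound to a carbonyl carbon and a saturated chain carbon. The difference between the core of compound 2 and the core of compound 3 is not broken down here.

Among the compounds with values here, because the only measured example of this kind of change gave a 1.9-fold higher number from compound 2 to compound 1 (0.27 log units; within the scatter), the step from compound 3 to compound 4 is expected to be of similar modest size, a 1.2-fold higher number from compound 3 to compound 4 (0.09 log units; within the scatter). Compound 4 is therefore estimated at 15000 nM, with a likely range from 6000 nM to 40000 nM.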

Compound 4, half-maximal inhibitory concentration: 4200 nM
The estimate for compound 4 lay 3.6-fold (0.55 log units) above the measured number, and the stated range ends above it.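

In this assay, replacing methyl with hydrogen on the acyl chain, which turns isopropylcarbonyl into propanoyl, gives a 2.9-fold lower number from compound 3 to compound 4 (0.46 log units; beyond the scatter). Set beside the earlier example, this shows that the same kind of replacement did not carry the same result from one core to the other in these two pairs: the same change on two cores in this assay, a 1.9-fold higher number (0.27 log units; within the scatter) from compound 2 to compound 1 and a 2.9-fold lower number (0.46 log units; beyond the scatter) from compound 3 to compound 4, 5.4-fold (0.73 log units) apart, beyond the scatter of two such steps. It does not show why the two steps differ, since the pairs differ both in their cores and in where the methyl sits, and two steps are too few to give a rule for the whole series.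

Groups such as acetyl or butanoyl, a longer chain on the carbonyl, would show whether the number in this assay keeps moving as this chain changes or whether the drop belongs to propanoyl alone. Placing the isopropylcarbonyl and propanoyl groups on the core of compound 1 would also help to separate the part played by the core from the part played by the place of the change, a question the compounds shown leave open.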